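This account rests on a few compounds, and the source may have more. Where it says the series, first, only, none or still open, it means among the compounds named here.

Compound 3 `CCN(CC)c1cc2[nH]c(C3CCCCC3)nc2cc1NC(=O)c1ccc(Br)cc1` is the starting point. In an ADME assay on Vero cells (Chlorocebus sabaeus) for cytotoxicity, read by resazurin assay, with a stated time of 3 days (a lower number here means a stronger inhibitor, a higher number a weaker inhibitor), compound 3 gives > 100 ug/mL, which is a limit of the assay and not a number. Its neighbour compound 2 `C=Cc1cccc(C(=O)Nc2cc3nc(C4CCCCC4)[nH]c3cc2N(CC)CC)c1` gives > 100 ug/mL in this assay, again a limit. Compound 1 `CCOCCOC(=O)Nc1cc2nc(C3CCCCC3)[nH]c2cc1N(C)C` gives > 100 ug/mL in this assay, also a limit. The step that the two limits leave unreadable from compound 2 to compound 3 therefore cannot be read in size or direction; all that can be said is the limit of > 100 ug/mL in this assay, at which 3 of the 3 values shown sit.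

Compound 4 `CCOCCOC(=O)Nc1cc2nc(C3CCCCC3)[nH]c2cc1N(CC)CC` is obtained from compound 3 by the change (2-ethoxyethoxy in place of 4-bromophenyl on a carbonyl carbon). Among the compounds with values here, the only measured step that touches this carbonyl position is the one from compound 2 to compound 3, and it is unreadable, so no size can be carried over. Compound 1 carries the same (2-ethoxyethoxy)carbonyl amino group and stands at its limit, and compound 3 stands at its limit, so the step of a number no higher from compound 3 to compound 4 (the limit leaves the size open) is expected to be none beyond the scatter. Compound 4 is accordingly expected to give about 100 ug/mL, between 50 ug/mL and 200 ug/mL, most probably reported as a limit.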

Compound 4, half-maximal inhibitory concentration: > 100 ug/mL
Compound 4 ended at the assay's limit (the forecaster's own chance of this, stated with the estimate: 85%); the middle value sits exactly at the limit.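

In this assay compound 4 gives > 100 ug/mL, which is a limit of the assay and not a number. Its steps to compound 1, compound 2 and compound 3 therefore cannot be read: the limit of > 100 ug/mL in this assay, at which 4 of the 4 values shown sit.

The compounds shown leave open what the true values are, and whether changing the group on the carbonyl carbon or on the aromatic carbon alters them at all.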